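The source may report more compounds than this note shows. Statements on the series, on what has been measured and on what is new or still open speak of the compounds shown alone.

Measured so far: compound 1 `C=CC(=O)N1CC(NC(=O)Cn2cc(C(=O)N3CCc4cc(Cl)ccc4C3)c3cc(Br)ccc32)C1` gives 1.67 h in a physicochemical assay for pharmacokinetics, read by LC-MS, in phosphate buffer, at pH 7.4, in the presence of a further agent that is not named here; a lower number here means that the compound disappears faster, a higher number that the compound lasts longer; compound 2 `C=CC(=O)N1CC(NC(=O)Cn2cc(C(=O)N3CCc4c(Cl)cccc4C3)c3cc(Br)ccc32)C1` gives 1.67 h.

Among the measured compounds shown here, compound 2 stands level with compound 1 in this assay; the only step available, no change at the digits printed from compound 1 to compound 2 (within the scatter), lies within the scatter. Compound 3 `C=CC(=O)N1CC(NC(=O)Cn2cc(C(=O)NCc3ccccc3)c3cc(Br)ccc32)C1` differs from compound 2 by a group of 8 heavy atoms (7 carbon, 1 nitrogen; one six-membered aromatic ring of carbon only) in place of a group of 11 heavy atoms (9 carbon, 1 nitrogen, 1 chlorine; one six-membered non-aromatic ring with 1 hetero atom, one six-membered aromatic ring of carbon only), on a carbonyl carbon. For the measured compounds named here, no measured step exchanges the group on that carbonyl carbon for benzylamino, and the one step in hand, no change at the digits printed from compound 1 to compound 2 (within the scatter), moved nothing beyond the scatter. No shift beyond the scatter is therefore expected for compound 3, which is estimated at 1.6 h, range 0.8 h to 3.2 h. The expected step is a 1.0-fold lower number from compound 2 to compound 3 (0.02 log units; within the scatter).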

Compound 3, half-life: 1.67 h
The estimate for compound 3 lay 1.0-fold (0.02 log units) below the measured number; the measured number falls inside the stated range.
By their numbers in this assay, from the lowest: compounds 1, 2 and 3 (each within the scatter of the next).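

In this assay benzylamino on the carbonyl carbon, in place of the group of 11 heavy atoms, shows no change at the digits printed from compound 2 to compound 3 (within the scatter) and no change at the digits printed from compound 1 to compound 3 (within the scatter) as the outcome of a change in the group itself. The earlier pair exchanged only groups of the same atom count; here the chlorine and the non-aromatic ring leave and a hydrogen-bond donor enters, with the half-life staying within the scatter. No data in hand give a reason for this flat result.

Still open, going by these compounds, is whether a carboxylic acid, a dimethylamino group or a phenethylamino chain on this carbonyl carbon would shift the half-life beyond the scatter. Also open, on these data alone, is whether any change elsewhere on the shared core would move it.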